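A Second Aryl Exchange at the Chain End

The compounds below may be only part of what the source reports. "The series", "measured", "known", "first", "only" and "open" are said of these compounds alone.

Of the compounds shown here, two have been measured in a functional assay on PC-3 cells (Homo sapiens) for cytotoxicity, read by MTT assay, with a stated time of 72 h; on this read-out higher numbers stand for weaker inhibition and lower numbers for stronger inhibition. Compound 1 `COc1cccc(/C=C/C(=O)Nc2cc(C(=O)c3cc(OC)c(OC)c(OC)c3)ccc2OC)c1` gives 4700 nM, and compound 2 `COc1ccc(C(=O)c2cc(OC)c(OC)c(OC)c2)cc1NC(=O)/C=C/c1ccc(F)c(F)c1` gives 8300 nM; the two lie within the scatter of each other, so compound 2 stands beside compound 1 rather than apart from it. Among the compounds with values here, the only measured step, a 1.8-fold higher number from compound 1 to compound 2 (0.25 log units; within the scatter), exchanges one aryl group for another at the same place. Compound 3 `COc1ccc(C(=O)c2cc(OC)c(OC)c(OC)c2)cc1NC(=O)/C=C/c1ccc([N+](=O)[O-])cc1` carries 4-nitrophenyl in place of 3,4-difluorophenyl on a double-bonded chain carbon bound to a double-bonded chain carbon. Because a 1.8-fold higher number from compound 1 to compound 2 (0.25 log units; within the scatter) stayed within the scatter, no step beyond the scatter is expected here either: a 1.0-fold lower number from compound 2 to compound 3 (0.02 log units; within the scatter). Compound 3 is therefore estimated at 8000 nM, within 3000 nM to 22000 nM.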

Compound 3, half-maximal inhibitory concentration: 10400 nM
Beside the measured number, compound 3's estimate is 1.3-fold (0.11 log units) below it; the measured number falls inside the stated range.
By their numbers in this assay, from the lowest: compounds 1, 2 and 3 (each within the scatter of the next, the first and the last beyond it).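

Set against 3-methoxyphenyl, 4-nitrophenyl on a double-bonded chain carbon gives the first exchange at this place to pass the scatter in this assay with a 2.2-fold higher number from compound 1 to compound 3 (0.34 log units; beyond the scatter) and even this step is modest. Set against 3,4-difluorophenyl, the same group gives only a 1.3-fold higher number from compound 2 to compound 3 (0.10 log units; within the scatter) so compound 2 and compound 3 cannot be told apart. No evidence at hand accounts for either step.

The compounds shown leave open how an amine or a carboxylic acid on this aromatic ring would read. They also leave open whether a longer chain before the ring would shift the number.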